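Amide substituent change in a sulfonyl pyrrolidine series

A few compounds are considered here, and "the series" means these few. Any claim that something is new, unique, unknown or untested is made for them only; others in the source may bear on it.

Measured so far:
- compound 2 `O=C(O)C12CCC(C(=O)N3CC[C@](c4ccc(C(F)(C(F)(F)F)C(F)(F)F)cc4)(S(=O)(=O)c4ccc(F)cc4)C3)(CC1)C2`: "not determined" (no result reported)
- compound 1 `O=C(O)[C@H]1CC[C@](F)(C(=O)N2CC[C@](c3ccc(C(F)(C(F)(F)F)C(F)(F)F)cc3)(S(=O)(=O)c3ccc(F)cc3)C2)CC1`: "not determined" (no result reported)
- compound 3 `O=C([C@H]1CC[C@H](c2nnn[nH]2)CC1)N1CC[C@](c2ccc(C(F)(C(F)(F)F)C(F)(F)F)cc2)(S(=O)(=O)c2ccc(F)cc2)C1`: 100%

Compound 2 stands without a number in an ADME assay on microsomes from liver (Homo sapiens) for metabolic stability, with a stated time of 10 min; a higher number here means that more of the compound is left, a lower number that less of the compound is left; compound 1 is in the same position. Only compound 3 has a result, and it gives 100% in this assay. The unmeasured compound 4 `CCC1(C(=O)N2CC[C@](c3ccc(C(F)(C(F)(F)F)C(F)(F)F)cc3)(S(=O)(=O)c3ccc(F)cc3)C2)CCS(=O)(=O)CC1` differs from compound 2 in one place: a group of 10 heavy atoms (7 carbon, 2 oxygen, 1 sulfur; one six-membered non-aromatic ring with 1 hetero atom) in place of a group of 10 heavy atoms (8 carbon, 2 oxygen; 2 five-membered non-aromatic rings of carbon only), on a carbonyl carbon. Within the data shown here, no measured step on this change exists, so nothing can be said of its size or direction from compound 2 itself. With compound 3 returning 100% as the single reference in this assay, a high value for compound 4 is expected. Compound 4 is estimated at 85%, with an expected range from 55% to 100%.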

Compound 4, percent of the compound remaining: 3%
For compound 4 the middle estimate is 82 percentage points above the measured one; the whole stated range lies above it.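

In this assay, the group on the carbonyl carbon alone can decide the read-out with the shared core unchanged: 4-ethyl-1,1-dioxothian-4-yl in place of 4-(1H-tetrazol-5-yl)cyclohexyl gives a number 97 percentage points lower from compound 3 to compound 4 (beyond the scatter). The two groups differ in ring and in substituent at once, so this single step does not separate the two changes. Nothing at hand accounts for the size of this step.

Still open, as far as these compounds go, is whether the 1,1-dioxothian ring stays this low with a methyl group or an amine in place of the ethyl group. From the compounds shown here alone, a tetrazole carried on that ring is equally open.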